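A few compounds are considered here, and "the series" means these few. Any claim that something is new, unique, unknown or untested is made for them only; others in the source may bear on it.

The three measured compounds, all tested in an ADME assay on microsomes from liver (Homo sapiens) for metabolic stability, read by LC-MS, using NADPH, with stated times of 5 min and 30 min, tested at 1 uM; on this read-out higher numbers stand for fast clearance and lower numbers for slow clearance:

Compound 1 `Cc1nccn1-c1cnc(NCc2c(F)ccc3c2CCO3)c2cn[nH]c(=O)c12` gives 8 mL.min-1.g-1.
Compound 2 `CN(c1ccn(C)n1)c1cnc(NCc2c(F)ccc3c2CCO3)n2cnnc12` gives 11 mL.min-1.g-1.
Compound 3 `Cc1nn(C)cc1-c1cnc(NCc2c(F)ccc3c2CCO3)c2cn[nH]c(=O)c12` gives 27 mL.min-1.g-1.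

Compound 2 stands second highest of the three numbers in this assay; compound 1 sits within the usual scatter of it, while compound 3 lies clearly higher. Compound 4 `Fc1ccc2c(c1CNc1ncc(Nc3ccccc3)c3nncn13)CCO2` differs from compound 2 in one place: anilino in place of methyl(1-methyl-1H-pyrazol-3-yl)amino on an aromatic carbon. Going by the values given here, the only measured step, a 3.4-fold higher number from compound 1 to compound 3 (0.53 log units; beyond the scatter), concerns a different exchange on a different shared core and so does not bear directly on this change; no measured pair shows what replacing the pyrazolylamino group by anilino does. A modest rise at most is expected, a 1.6-fold higher number from compound 2 to compound 4 (0.21 log units; within the scatter). Compound 4 is therefore estimated at 18 mL.min-1.g-1, with a likely range from 8 mL.min-1.g-1 to 40 mL.min-1.g-1.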

Compound 4, intrinsic clearance in microsomes: 20 mL.min-1.g-1
Compound 4: the middle estimate sits 1.1-fold (0.05 log units) below what was measured, and the stated range covers the measured number.
By their numbers in this assay, from the lowest: compounds 1, 2, 4 and 3 (each within the scatter of the next, the first and the last beyond it).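

In this assay, placing anilino on this aromatic carbon in place of methyl(1-methyl-1H-pyrazol-3-yl)amino gives a 1.8-fold higher number from compound 2 to compound 4 (0.26 log units; within the scatter), so the two compounds cannot be told apart. At this position, a carbon-only six-membered ring can thus replace a five-membered aromatic ring with 2 hetero atoms without a change beyond the scatter. Nothing on hand explains this result. Going by these compounds, what a saturated amine such as morpholine would give on this carbon remains open. So does whether the same exchange would read alike on the core of compound 1.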